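This account rests on a few compounds, and the source may have more. Where it says the series, first, only, none or still open, it means among the compounds named here.

Compound 1 `COC(=O)/C=C/c1cccc(N(Cc2ccc(/C=C/c3c(C)cc(C)cc3C)cc2)C(=O)C(C)C)c1` has the lowest number of the three compounds in an assay on isolated protein with Bile acid receptor (Homo sapiens) as the target (on this read-out lower numbers stand for an effect already at smaller amounts and higher numbers for an effect only at larger amounts of compound), giving 149 nM. Among the compounds with values here, compound 3 `COC(=O)/C=C/c1cccc(N(Cc2ccc(/C=C/c3ccccn3)cc2)C(=O)C2CCCCC2)c1` gives 309 nM, and compound 2 `COC(=O)/C=C/c1cccc(N(Cc2ccc(/C=C/c3c(C)cc(C)cc3C)cc2)C(=O)NC(C)C)c1` gives 431 nM; the change a 2.9-fold higher number from compound 1 to compound 2 (0.46 log units; beyond the scatter) is the one directly measured step. Compound 4 `COC(=O)/C=C/c1cccc(N(Cc2ccc(-c3ccc(SC)cc3)cc2)C(=O)C(C)C)c1` differs from compound 1 in one place: 4-(methylsulfanyl)phenyl in place of 2-(2,4,6-trimethylphenyl)ethenyl on an aromatic carbon. Within the data shown here, no measured step touches this end of the molecule; the step from compound 1 to compound 2 lies at the carbonyl, and compound 3 differs from compound 1 in two places at once, so its value only shows that changing the styryl part together with the acyl group left the number moderately higher. The expected step of a 2.7-fold higher number from compound 1 to compound 4 (0.43 log units; beyond the scatter) is therefore a modest rise with wide uncertainty, and compound 4 is estimated at 400 nM, within 100 nM to 1600 nM.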

Compound 4, half-maximal effective concentration: 51 nM
Compound 4: the middle estimate sits 7.8-fold (0.89 log units) above what was measured; measured number outside the range, below it.
By their numbers in this assay, from the lowest: compound 4; then compound 1; then compounds 3 and 2 (each within the scatter of the next).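

In this assay, putting 4-(methylsulfanyl)phenyl in place of 2-(2,4,6-trimethylphenyl)ethenyl gives a 2.9-fold lower number from compound 1 to compound 4 (0.47 log units; beyond the scatter). This position, on an aromatic carbon para to a large group, therefore keeps its effect without the double bond, and with fewer heavy atoms. No measurement at hand gives a reason for this drop. The compounds shown leave open whether the sulfur matters, which a methoxy group in place of methylsulfanyl would test. They also leave open whether isopropylamino on the carbonyl would raise the number here too.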